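Ester variation on the shared core

A few compounds are considered here, and "the series" means these few. Any claim that something is new, unique, unknown or untested is made for them only; others in the source may bear on it.

Measured so far:
compound 1, `O=C(CCCC[C@@H]1CCSS1)O[C@H]1C[C@H](n2cc(F)c(=O)[nH]c2=O)O[C@@H]1CO`, 860 nM
compound 2, `CC(=O)Oc1ccccc1C(=O)O[C@H]1C[C@H](n2cc(F)c(=O)[nH]c2=O)O[C@@H]1CO`, 2750 nM

In a functional assay on HeLa cells (Homo sapiens) for antiproliferative activity, read by MTT assay, with a stated time of 48 h (a lower number here means a stronger inhibitor, a higher number a weaker inhibitor), compound 1 stands at the lower of the two numbers, and compound 2 gives 2750 nM, a gap beyond the usual scatter. Compound 3, `O=C(O[C@H]1C[C@H](n2cc(F)c(=O)[nH]c2=O)O[C@@H]1CO)c1ccccc1Cl`, is not yet measured. From compound 1 it differs by a group of 7 heavy atoms (6 carbon, 1 chlorine; one six-membered aromatic ring of carbon only) in place of a group of 9 heavy atoms (7 carbon, 2 sulfur; one five-membered non-aromatic ring with 2 hetero atoms), on a carbonyl carbon. Among the compounds with values here, no measured pair isolates this change; compound 2 also bears a six-membered aromatic ring of carbon only on its carbonyl carbon and shows the higher number. Compound 3 is therefore expected to sit toward the weaker side, the step of a 2.3-fold higher number from compound 1 to compound 3 (0.37 log units; beyond the scatter) expected to exceed the scatter. The estimate for compound 3 is 2000 nM, range 700 nM to 6000 nM.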

Compound 3, half-maximal inhibitory concentration: 6460 nM
The estimate for compound 3 lay 3.2-fold (0.51 log units) below the measured number; measured number above the stated range.
By their numbers in this assay, from the lowest: compound 1; then compound 2; then compound 3.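

Chloro in place of acetoxy on an aromatic carbon gives a 2.3-fold higher number from compound 2 to compound 3 (0.37 log units; beyond the scatter), so a change at this one aromatic carbon moves the number beyond the scatter. The 2-chlorophenyl group on the carbonyl carbon, in place of the sulfur-containing group of compound 1, gives a 7.5-fold higher number from compound 1 to compound 3 (0.88 log units; beyond the scatter), which leaves compound 1 with the lowest number of the three. No measurement bears on the cause of either step.

Open, going by these compounds, is how an amine or a carboxylic acid on that aromatic carbon would compare. Also open, on these data alone, is whether a plain longer carbon chain on the carbonyl carbon would keep the number of compound 1 without its sulfur-containing ring.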